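Swapping the Sulfonyl Aryl: From Pyridine to Chlorophenyl

A few compounds are considered here, and "the series" means these few. Any claim that something is new, unique, unknown or untested is made for them only; others in the source may bear on it.

Compound 2 `O=C(NCc1ccc(CNS(=O)(=O)c2cccnc2)cc1)c1ccc(F)cc1` is one of two analogues in this series that carry a variable aromatic group on the sulfonyl sulfur. In an assay on MDA-MB-231 cells for binding affinity to C-X-C chemokine receptor type 4 (Homo sapiens), read by fluorescence and microscopy, with stated times of 10 min and 30 min (a lower number here means that less compound is needed, a higher number that more compound is needed for the effect), compound 2 gives 1000 nM. Its nearest neighbour, compound 1 `O=C(NCc1ccc(CNS(=O)(=O)c2ccc([N+](=O)[O-])cc2)cc1)c1ccc(F)cc1`, gives 1000 nM in this assay, so the two stand level: the step of no change at the digits printed from compound 1 to compound 2 (within the scatter) lies within the scatter of repeated measurements.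

Compound 3 `O=C(NCc1ccc(CNS(=O)(=O)c2ccccc2Cl)cc1)c1ccc(F)cc1` extends the same series by a further exchange at that position, (2-chlorophenyl in place of pyridin-3-yl on a sulfonyl sulfur). Among the measured compounds shown here, the only measured step at this position, no change at the digits printed from compound 1 to compound 2 (within the scatter), left the effective concentration unchanged, and that is the sole guide available, since no analogue with chlorine on this ring has been measured. The expected step of no change at the digits printed from compound 2 to compound 3 (within the scatter) is therefore flat. Compound 3 is expected to give about 1000 nM, most likely between 400 nM and 2500 nM.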

Compound 3, effective concentration (reported as EC, without a stated level of effect): 1000 nM
Compound 3: the middle estimate sits on the measured number at the digits printed, and the stated range covers the measured number.
By their numbers in this assay, from the lowest: compounds 1, 2 and 3 (each within the scatter of the next).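

In this assay, replacing pyridin-3-yl with 2-chlorophenyl on the sulfonyl sulfur gives no change at the digits printed from compound 2 to compound 3 (within the scatter), and replacing 4-nitrophenyl with the same group gives no change at the digits printed from compound 1 to compound 3 (within the scatter). The flat result therefore now extends to a ring of carbon only that bears chlorine, so this position has tolerated the loss of the ring nitrogen of pyridin-3-yl and the nitro group of 4-nitrophenyl without any change at the digits printed. Nothing measured explains why these three aromatic groups stand level. The compounds shown leave open whether a non-aromatic group on the sulfonyl sulfur, such as an amine, a carboxylic acid or a longer alkyl chain, would shift the value. They also leave open whether changes elsewhere in the shared core would do so.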